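Compound 2 to compound 3: an aryl swap at the limit

The compounds below may be only part of what the source reports. "The series", "measured", "known", "first", "only" and "open" are said of these compounds alone.

Compound 1 (`Cc1ccc(Nc2ncc(C(F)(F)F)c(N3Cc4cccc(N(C)S(C)(=O)=O)c4C3)n2)cc1C`) and compound 2 (`Cc1ccc(Nc2ncc(C(F)(F)F)c(N3Cc4cccc(N(C)S(C)(=O)=O)c4C3)n2)c(C)c1`) share one core and differ only in the dimethylphenyl group. In a functional assay on OVCAR-3 cells (Homo sapiens) for antiproliferative activity, read by spectrophotometry, with a stated time of 2 days (a lower number here means a stronger inhibitor of growth, a higher number a weaker inhibitor of growth), compound 1 gives > 30000 nM, which is a limit of the assay and not a number. In this assay compound 2 gives > 30000 nM, again only a limit. The position of the series is therefore simple: the limit of > 30000 nM in this assay, at which 2 of the 2 values shown sit.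

Compound 3 (`COc1cc(Nc2ncc(C(F)(F)F)c(N3Cc4cccc(N(C)S(C)(=O)=O)c4C3)n2)cc(C(F)(F)F)c1`) keeps the shared core and changes the same place, on a nitrogen on an aromatic ring: 3-methoxy-5-(trifluoromethyl)phenyl in place of 2,4-dimethylphenyl on a nitrogen on an aromatic ring. The 2,4-dimethylphenyl leaves and the 3-methoxy-5-(trifluoromethyl)phenyl enters.

For the measured compounds named here, the only measured step that bears on this change is a step that the two limits leave unreadable from compound 1 to compound 2. It gives no size and no direction to carry forward. Going by the values given here, with that step as the sole guide, no change beyond the scatter is expected in this assay, and another limit is the likeliest reading. The expected step is a number no higher from compound 2 to compound 3 (the limit leaves the size open). For compound 3 the estimate is 30000 nM, with the expected range running from 10000 nM to 60000 nM.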

Compound 3, concentration for 50% growth inhibition: > 30000 nM
Compound 3: only a limit was reported; the forecaster's own chance of this, stated with the estimate: 70%; the middle value lies on the limit itself.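

Compound 3 gives > 30000 nM in this assay, which is a limit of the assay and not a number. No step among compound 1, compound 2 and compound 3 can be read, and the series stands at: the limit of > 30000 nM in this assay, at which 3 of the 3 values shown sit.

The compounds shown leave open how far each lies from that limit, and whether any other group at this place would give a measurable value in this assay.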